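The compounds below may be only part of what the source reports. "The series", "measured", "known", "first", "only" and "open" are said of these compounds alone.

Compound 1 `CN(CCNCc1cn(C(C)(C)C)nn1)CCNc1ccnc2cc(Cl)ccc12` and compound 2 `CN(CCNCc1cn(-c2nc3ccccc3[nH]2)nn1)CCNc1ccnc2cc(Cl)ccc12` share one core and differ only in the group on the triazole nitrogen. In a functional assay on HCC827 cells (Homo sapiens) for antiproliferative activity, read by sulforhodamine B assay, with a stated time of 72 h (a higher number here means a weaker inhibitor, a lower number a stronger inhibitor), compound 1 gives 56000 nM, and compound 2 gives 32000 nM. Among the compounds with values here, the step of a 1.8-fold lower number from compound 1 to compound 2 (0.24 log units; within the scatter) is within the scatter, so compound 2 stands alongside compound 1, the only other number, without a separation that can be read as a real gain.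

Compound 3 `CN(CCNCc1cn(CCC(=O)Nc2ccccn2)nn1)CCNc1ccnc2cc(Cl)ccc12` carries 2-((pyridin-2-yl)carbamoyl)ethyl in place of 1H-benzimidazol-2-yl on an aromatic nitrogen. Within the data shown here, the one measured step that bears on this position, a 1.8-fold lower number from compound 1 to compound 2 (0.24 log units; within the scatter), exchanged the same nitrogen substituent and stayed within the scatter, so a change of substituent here has so far shifted nothing beyond it. For compound 3 the expected step in this assay is therefore a 1.1-fold higher number from compound 2 to compound 3 (0.04 log units; within the scatter), none beyond the scatter. Compound 3 is estimated at 35000 nM, with a range from 12000 nM to 100000 nM.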

Compound 3, half-maximal inhibitory concentration: > 200000 nM
Compound 3 ended at the assay's limit (the forecaster's own chance of this, stated with the estimate: 10%); middle value at least 5.7-fold (0.75 log units) away from the limit.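

Compound 3 stands at a limit of this assay, not at a number: the limit of > 200000 nM in this assay, at which 1 of the 3 values shown sits. Within the data shown here, the earlier exchange on this nitrogen stayed within the scatter, whereas this change gives the first steps beyond it, an at least 6.2-fold higher number from compound 2 to compound 3 (0.79 log units; beyond the scatter) and an at least 3.5-fold higher number from compound 1 to compound 3 (0.55 log units; beyond the scatter). The group on an aromatic nitrogen of the five-membered ring is therefore not indifferent in these compounds: 2-((pyridin-2-yl)carbamoyl)ethyl reads as weaker than both 1H-benzimidazol-2-yl and tert-butyl.

On these data alone, the full size of both steps remains open, as does the question of whether they go with the carbonyl-bearing chain or with the pyridine ring. A plain propyl chain, or a carboxylic acid or primary amine at the end of a chain on the same nitrogen, would help separate these parts.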